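Replacing (diethylamino)methyl with tert-butyl in compound 3

The compounds below may be only part of what the source reports. "The series", "measured", "known", "first", "only" and "open" are said of these compounds alone.

In an ADME assay on L6 cells (Rattus norvegicus) for cytotoxicity, with a stated time of 72 h (on this read-out lower numbers stand for stronger inhibition and higher numbers for weaker inhibition), compound 3 `CCN(CC)CC(=O)OC1CC2(N3CCCCC3)CC(c3ccccc3)C1C(c1ccccc1)C2` gives 23900 nM. That lies within the scatter of compound 1 `CCN(CC)CC(=O)OC1CC2(N(C)C)CC(c3ccccc3)C1C(c1ccccc1)C2`, which gives 30100 nM. Compound 2 `CC(C)(C)C(=O)OC1CC2(N3CCCC3)CC(c3ccccc3)C1C(c1ccccc1)C2` stands clearly lower at 7620 nM, a gap beyond the scatter from compound 3.

The next structure, compound 4 `CC(C)(C)C(=O)OC1CC2(N3CCCCC3)CC(c3ccccc3)C1C(c1ccccc1)C2`, has tert-butyl in place of (diethylamino)methyl on a carbonyl carbon. Going by the values given here, no measured step isolates this change. Among the compounds with values here, the only single-place step, a 1.3-fold lower number from compound 1 to compound 3 (0.10 log units; within the scatter), concerns another part of the molecule: piperidin-1-yl in place of dimethylamino on a saturated ring carbon. Its small size suggests that such an exchange need not move the number much, so the piperidin-1-yl group of compound 3 is not expected to set compound 4 apart.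

Within the data shown here, the best guide is compound 2, the only measured compound that already carries tert-butyl, at 7620 nM. Both compounds with (diethylamino)methyl read higher, although three compounds make a thin basis. A drop beyond the scatter is therefore expected, and the estimated change is a 3.0-fold lower number from compound 3 to compound 4 (0.48 log units; beyond the scatter). For compound 4 the expected value is 8000 nM, with an estimated range from 3800 nM to 17000 nM.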

Compound 4, half-maximal inhibitory concentration: 12000 nM
Estimate against measurement, compound 4: 1.5-fold (0.18 log units) below; the range from low to high includes it.
By their numbers in this assay, from the lowest: compounds 2, 4, 3 and 1 (each within the scatter of the next, the first and the last beyond it).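

In this assay, going by these compounds alone, the exchange on the carbonyl carbon can now be read on its own for the first time: tert-butyl in place of (diethylamino)methyl gives a 2.0-fold lower number from compound 3 to compound 4 (0.30 log units; within the scatter) and so no clear shift in the number. At this position, then, a group with no nitrogen and no hydrogen-bond acceptor reads much like one that carries both, at least with piperidin-1-yl on the saturated ring carbon. That ring carbon also gains a second reading, as piperidin-1-yl in place of pyrrolidin-1-yl gives a 1.6-fold higher number from compound 2 to compound 4 (0.20 log units; within the scatter) and joins a 1.3-fold lower number from compound 1 to compound 3 (0.10 log units; within the scatter) in showing that neither single exchange of an amine group there moves the number beyond the usual scatter; nothing among the available data explains why these steps are this small.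

The compounds shown leave open whether a carboxylic acid or a longer chain ending in an amine on the carbonyl carbon would give a step beyond the scatter. They also leave open whether morpholin-4-yl on the saturated ring carbon would do so.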